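The source may report more compounds than this note shows. Statements on the series, on what has been measured and on what is new or still open speak of the compounds shown alone.

Working notes on the series in an assay on HeLa cells for displacement of a labelled ligand from 5-hydroxytryptamine receptor 6 (Homo sapiens); on this read-out higher numbers stand for weaker inhibition and lower numbers for stronger inhibition.

Three compounds carry numbers. Compound 1 `Cc1ccc(Nc2nc3ccc(C)cn3c(=N)c2S(=O)(=O)c2ccccc2)nc1` gives 60 nM in this assay. Compound 2 `CSc1nc2ccc(Br)cn2c(=N)c1S(=O)(=O)c1ccccc1` gives 56 nM. Compound 3 `CSc1nc2ccc(C)cn2c(=N)c1S(=O)(=O)c1ccccc1` gives 1.3 nM, the lowest of the three numbers, with both steps to it beyond the scatter: a 46-fold lower number from compound 1 to compound 3 (1.66 log units; beyond the scatter) and a 43-fold lower number from compound 2 to compound 3 (1.63 log units; beyond the scatter). Compound 3 is therefore the reference point for the next change.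

Compound 4 `CSc1nc2c(Br)cc(C)cn2c(=N)c1S(=O)(=O)c1ccccc1` has not been measured. It differs from compound 3 by bromo in place of hydrogen on an aromatic carbon; the methyl group of compound 3 stays in place, and a bromine is added on an aromatic carbon of the six-membered aromatic ring with one nitrogen, two atoms from the ring nitrogen.

Neither measured step bears directly on this change. The step from compound 2 to compound 3 concerns a bromine exchanged for a methyl at another position, not a bromine added with the methyl retained, and the step from compound 1 to compound 3 concerns a different part of the core. The only hint available is that compound 2, which carries a bromine in place of the methyl, gives a much higher number than compound 3.

On that thin basis, a modest loss is expected for compound 4, a 3.8-fold higher number from compound 3 to compound 4 (0.59 log units; beyond the scatter), with wide uncertainty. The estimate for compound 4 is 5 nM, with a range from 1 nM to 40 nM.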

Compound 4, half-maximal inhibitory concentration: 126 nM
Beside the measured number, compound 4's estimate is 25-fold (1.40 log units) below it; measured number above the stated range.
By their numbers in this assay, from the lowest: compound 3; then compounds 2 and 1 (each within the scatter of the next); then compound 4.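

In this assay, the aromatic carbon two atoms from the ring nitrogen proves highly sensitive to this change: adding bromo with the methyl retained gives a 97-fold higher number from compound 3 to compound 4 (1.99 log units; beyond the scatter). For the compounds shown here, this is the first measured change at this carbon, and its step is of a size similar to a 43-fold lower number from compound 2 to compound 3 (1.63 log units; beyond the scatter), which concerns methyl and bromo at another position, so a large difference is not confined to that position or to the methylsulfanyl exchange in a 46-fold lower number from compound 1 to compound 3 (1.66 log units; beyond the scatter). No measurement here accounts for the higher number of compound 4, and the result fixes only the size of the step for this single group at this carbon.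

The compounds shown leave open whether the higher number belongs to bromo alone or would follow any group on this carbon, a question that fluoro, methoxy or an amine there could help to separate. Also open, on these data alone, is whether the step keeps its size when (5-methylpyridin-2-yl)amino stands in place of methylsulfanyl on the shared core.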